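A few compounds are considered here, and "the series" means these few. Any claim that something is new, unique, unknown or untested is made for them only; others in the source may bear on it.

Compound 1 `O=C(N1CCCN(Cc2ccc(OCc3ccccc3)cc2)CC1)n1cccn1` and compound 2 `N#Cc1cnn(C(=O)N2CCCN(Cc3ccc(OCc4ccccc4)cc3)CC2)c1` share one core; compound 3 `O=C(N1CCN(C(c2ccc3ccccc3c2)c2ccc3ccccc3c2)CC1)n1cccn1` and compound 4 `N#Cc1cnn(C(=O)N2CCN(C(c3ccc4ccccc4c3)c3ccc4ccccc4c3)CC2)c1` share another, and the difference between the two cores is not broken down here. In an assay on membranes from brain for binding affinity to Monoacylglycerol lipase ABHD6 (Mus musculus), read by fluorescence, with stated times of 1 h and 30 min (a higher number here means a weaker inhibitor, a lower number a stronger inhibitor), compound 1 gives 960 nM, and compound 2 gives 85 nM. The change between them, (cyano in place of hydrogen on an aromatic carbon), produced a step of an 11-fold lower number from compound 1 to compound 2 (1.05 log units; beyond the scatter).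

For compound 3 the assay reports only a limit, > 100000 nM, which is the limit of > 100000 nM in this assay, at which 1 of the 3 values shown sits. Compound 4 carries the same change on the second core, (cyano in place of hydrogen on an aromatic carbon), and the place is identical in both pairs. Going by the values given here, the step of an 11-fold lower number from compound 1 to compound 2 (1.05 log units; beyond the scatter) is the only measured precedent for the cyano entering. Applied to compound 3, whose value is a limit and not a number, it would still leave compound 4 at a weak level; the expected step to compound 4 is estimated at a step that the limit leaves unreadable from compound 3 to compound 4, resting on the size of that single earlier step. In this assay compound 4 is therefore expected to give about 150000 nM, with a plausible range from 20000 nM to 1000000 nM, and a real chance that only a limit is reported again.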

Compound 4, half-maximal inhibitory concentration: 560 nM
Compound 4: middle estimate off by 270-fold (2.43 log units), on the high side; the measured number lies below the stated range.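

In this assay the change from 1H-pyrazol-1-yl to 4-cyano-1H-pyrazol-1-yl gives an at least 170-fold lower number from compound 3 to compound 4 (2.25 log units; beyond the scatter), the same direction as on the core of compound 1. The direction carries over from one core to the other, but the size of the step does not: the same change on two cores in this assay, an 11-fold lower number (1.05 log units; beyond the scatter) from compound 1 to compound 2 and an at least 170-fold lower number (2.25 log units; beyond the scatter) from compound 3 to compound 4, at least 15-fold (1.19 log units) apart, beyond the scatter of two such steps Compound 3 gives only a limit, > 100000 nM, so the second step has no known upper size, and two pairs give no rule for how large the step would be on a further core.

Still open, on these data alone, is whether another group on the same aromatic carbon, such as a carboxylic acid, a primary amide or a trifluoromethyl group, would give a step like that of the cyano. The two cores also differ in more than one place, and which of those differences goes with the larger step remains unresolved.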